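Removing the last chloro from the dichloro/chloro series

A few compounds are considered here, and "the series" means these few. Any claim that something is new, unique, unknown or untested is made for them only; others in the source may bear on it.

Compound 2 `COc1cc(CCc2ccc(Cl)cc2)cc(OC)c1O` carries the lowest number of the three measured compounds in a functional assay on HCT-116 cells (Homo sapiens) for antiproliferative activity, read by MTT assay, with a stated time of 72 h (on this read-out higher numbers stand for weaker inhibition and lower numbers for stronger inhibition), giving 330 nM. Compound 1 `COc1cc(CCc2ccc(Cl)c(Cl)c2)cc(OC)c1O` gives 1860 nM in this assay, and compound 3 `COc1cc(CCc2ccc(Cl)cc2Cl)cc(OC)c1O` gives 2980 nM; both steps from compound 2 to these lie beyond the scatter, so compound 2 is the strongest inhibitor of the set.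

Compound 4 `COc1cc(CCc2ccccc2)cc(OC)c1O` differs from compound 2 in one place: hydrogen in place of chloro on an aromatic carbon. The change sits on an aromatic carbon of the six-membered carbon-only ring, para to a large group.

Within the data shown here, two measured steps bear on it, both involving chloro on an aromatic carbon of the same ring. a 5.6-fold lower number from compound 1 to compound 2 (0.75 log units; beyond the scatter) shows that losing a chloro lowered the number, and a 9.0-fold higher number from compound 2 to compound 3 (0.96 log units; beyond the scatter) shows that gaining one raised it. Neither step concerns the position changed here, so they give direction only loosely. On that basis compound 4 is expected to land near compound 2 or modestly below it, with a 1.5-fold higher number from compound 2 to compound 4 (0.18 log units; within the scatter) as the expected step.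

The estimate for compound 4 in this assay is 500 nM, within a range of 150 nM to 2000 nM.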

Compound 4, half-maximal inhibitory concentration: 530 nM
Compound 4: middle estimate off by 1.1-fold (0.03 log units), on the low side, within the range that was stated.
By their numbers in this assay, from the lowest: compounds 2 and 4 (each within the scatter of the next); then compounds 1 and 3 (each within the scatter of the next).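

Among these compounds, the chloro para to a large group on the six-membered aromatic ring of carbon only is the first substituent whose exchange leaves the number within the scatter: hydrogen in place of chloro gives a 1.6-fold higher number from compound 2 to compound 4 (0.21 log units; within the scatter) in this assay and compound 2 and compound 4 cannot be told apart on this read-out. The steps that differ by a chloro at other positions read otherwise, with a 5.6-fold lower number from compound 1 to compound 2 (0.75 log units; beyond the scatter) and a 9.0-fold higher number from compound 2 to compound 3 (0.96 log units; beyond the scatter) both beyond the scatter, so among these compounds the size of the step depends on which aromatic carbon carries the chloro, and the chloro of compound 2 is not needed to keep the number of compound 2 in this assay. No measurement at hand accounts for this difference between positions.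

How a fluoro, a methoxy, an amine or a carboxylic acid would read at this same place remains open, since hydrogen and chloro are the only two substituents shown there. Also open, on these data alone, is whether a longer chain between the two rings would keep the number of compound 4 in this assay or shift it.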